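The compounds below may be only part of what the source reports. "The series", "measured", "known", "first", "only" and "open" are said of these compounds alone.

In a functional assay on HCT-116 cells (Homo sapiens) for inhibition, read by sulforhodamine B assay, with a stated time of 48 h, tested at 10 uM (on this read-out higher numbers stand for a weaker effect at the one concentration tested and lower numbers for a stronger effect), compound 3 `COc1cc2cc(Oc3ccc(NC(=O)Nc4ccc(C(F)(F)F)cc4)cc3)c(C)nc2cc1OC` gives 47.2%. Among the three measured compounds this is the second highest number. Compound 1 `COc1cc2cc(Oc3ccc(NC(=O)Nc4ccccc4)cc3)c(C)nc2cc1OC` gives 42.6%, and the two are separated by a number 4.6 percentage points higher from compound 1 to compound 3 (within the scatter). Compound 2 `COc1cc2cc(Oc3ccc(NC(=O)Nc4ccc(C)cc4)cc3)c(C)nc2cc1OC` gives 107%, and the gap here is a number 59.8 percentage points lower from compound 2 to compound 3 (beyond the scatter). Compound 4 `COc1cc2cc(Oc3ccc(NC(=O)Nc4cccc(C(F)(F)F)c4)cc3)c(C)nc2cc1OC` has not yet been measured in this assay. Its difference from compound 3 is 3-(trifluoromethyl)phenyl in place of 4-(trifluoromethyl)phenyl on an amide-type nitrogen. Within the data shown here, no measured step moves a group from one place on that ring to another, so nothing directly matches this change. The two steps that involve the trifluoromethyl group, a number 4.6 percentage points higher from compound 1 to compound 3 (within the scatter) and a number 59.8 percentage points lower from compound 2 to compound 3 (beyond the scatter), swap it for hydrogen or methyl rather than relocating it, and they show that this ring can give results spread over a wide span. With no closer guide, no step beyond the scatter is expected, though the uncertainty is large. For compound 4 the estimate is 50%, expected to fall between 30% and 85%. That estimate corresponds to an expected step of a number 2.8 percentage points higher from compound 3 to compound 4 (within the scatter).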

Compound 4, a percentage reported as activity, at one concentration (the size of the read-out at that concentration, not a potency): 6.71%
The estimate for compound 4 lay 43.3 percentage points above the measured number; the measured number lies below the stated range.
By their numbers in this assay, from the lowest: compound 4; then compounds 1 and 3 (each within the scatter of the next); then compound 2.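

Moving the trifluoromethyl group on the ring matters even though the atoms stay the same: in this assay, 3-(trifluoromethyl)phenyl in place of 4-(trifluoromethyl)phenyl on the amide-type nitrogen gives a number 40.5 percentage points lower from compound 3 to compound 4 (beyond the scatter) and so a much stronger effect at the one concentration tested. The earlier compounds shown here showed no change beyond the scatter on adding trifluoromethyl to the plain phenyl ring, but in this new place the same addition gives a number 35.9 percentage points lower from compound 1 to compound 4 (beyond the scatter). The contrast with 4-methylphenyl is larger still, with a number 100.3 percentage points lower from compound 2 to compound 4 (beyond the scatter), so among these four compounds the outcome turns on both the group and where it sits. Nothing available explains why the place of the group matters so much. On these data alone, it also remains open whether a chlorine atom or a nitrile, in the place the trifluoromethyl takes in 3-(trifluoromethyl)phenyl, would give a similarly low number.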